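Piperidinyl sulfonyl quinolines: dropping the carbamoyl

The source may report more compounds than this note shows. Statements on the series, on what has been measured and on what is new or still open speak of the compounds shown alone.

Measured so far:
compound 1 `NC(=O)C1CCN(c2c(S(=O)(=O)c3ccccc3)cnc3ccccc23)CC1` — 24.8%
compound 2 `COc1ccc(S(=O)(=O)c2cnc3ccc(C)cc3c2N2CCC(C)CC2)cc1Cl` — 93%

In an assay on isolated protein for displacement of a labelled ligand from metabotropic glutamate receptor 5 (Homo sapiens), with a stated time of 60 min, tested at 1 uM (on this read-out lower numbers stand for less inhibition and higher numbers for more inhibition at the one concentration tested (going by the name of the read-out)), compound 1 gives 24.8% and stands lowest of the two numbers at hand. Compound 2, which differs from it in several places at once, gives 93% in this assay, a gap beyond the usual scatter; no single change links the two, so only the two values themselves are shown.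

Compound 3 `O=S(=O)(c1ccccc1)c1cnc2ccccc2c1N1CCCCC1` is not yet measured. It differs from compound 1 in one place: hydrogen in place of carbamoyl on a saturated ring carbon. Among the compounds with values here, no step between measured compounds bears on this exact change. Compound 3 is expected to give 35% in this assay, within 8% to 70%. Within the data shown here, the expected step of a number 10.2 percentage points higher from compound 1 to compound 3 (beyond the scatter) is thus estimated to fall at most modestly upward, not clearly beyond the scatter, since the only compound without a carbamoyl on that ring, compound 2 at 93%, differs in too many other places to anchor the estimate.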

Compound 3, a percentage reported as inhibition, at one concentration (the size of the read-out at that concentration, not a potency): 71.4%
Estimate against measurement, compound 3: 36.4 percentage points below; measured number outside the range, above it.
By their numbers in this assay, from the lowest: compound 1; then compound 3; then compound 2.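

In this assay, the change from 4-carbamoylpiperidin-1-yl to piperidin-1-yl gives a number 46.6 percentage points higher from compound 1 to compound 3 (beyond the scatter) on an otherwise unchanged core. Within the data shown here, this is the first comparison that isolates one place, and it shows that this saturated ring carbon, three ring bonds from the ring nitrogen, can strongly affect the read-out: inhibition at the one concentration tested is much higher with hydrogen there than with carbamoyl. Nothing at hand accounts for the size or direction of this step.

On these data alone, whether a carboxylic acid or a primary amine on the same ring carbon would read closer to hydrogen or to carbamoyl remains open. Also open, as far as these compounds go, is whether the carbamoyl costs as much on a core carrying the other substituents of compound 2.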